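Dropping the Second Ester: From Compound 3 to Compound 4

The source may report more compounds than this note shows. Statements on the series, on what has been measured and on what is new or still open speak of the compounds shown alone.

Three measured compounds share one core and differ only in the fatty esters attached to it. Compound 1 `CCCCCC(=O)O[C@H]1[C@H](O)[C@H](n2ccc(N)nc2=O)O[C@@H]1CO` carries a hexanoyl ester on one hydroxyl of the core; compound 2 `CCCCCCCCCCCC(=O)O[C@H]1[C@H](O)[C@H](n2ccc(N)nc2=O)O[C@@H]1CO` carries a dodecanoyl ester at the same place; compound 3 `CCCCCCCCCCC(=O)OC[C@H]1O[C@@H](n2ccc(N)nc2=O)[C@@H](O)[C@@H]1OC(=O)CCCCCCCCCC` carries two undecanoyl esters, one at that place and one on an oxygen on a saturated carbon. In a functional assay on HeLa cells (Homo sapiens) for cytotoxicity, read by cell counting, with a stated time of 48 h (a higher number here means that more compound is needed for the effect, a lower number that less compound is needed), compound 1 gives 0.05 ug/mL, compound 2 gives 0.08 ug/mL, and compound 3 gives 0.4 ug/mL, the highest number of the three, with its gap to each of the others beyond the scatter of repeated measurements.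

Compound 4 `CCCCCCCCCCC(=O)O[C@H]1[C@H](O)[C@H](n2ccc(N)nc2=O)O[C@@H]1CO` is compound 3 with one ester taken away: hydrogen in place of decylcarbonyl on an oxygen on a saturated carbon. What remains is a single undecanoyl ester at the place where compound 1 and compound 2 carry theirs, so compound 4 sits between them in chain length. For the measured compounds named here, the one measured single change, a 1.6-fold higher number from compound 1 to compound 2 (0.20 log units; within the scatter), shows that lengthening this chain hardly moves the number. Going by the values given here, no measured step removes a second ester, yet the two mono-esters both give much lower numbers than the di-ester compound 3.

Given the numbers of compound 1 and compound 2, compound 4 is expected to come in at 0.07 ug/mL, within a range from 0.035 ug/mL to 0.15 ug/mL. That expectation means an estimated step of a 5.7-fold lower number from compound 3 to compound 4 (0.76 log units; beyond the scatter), a fall beyond the scatter.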

Compound 4, concentration for half-maximal effect: 0.04 ug/mL
Estimate against measurement, compound 4: 1.8-fold (0.24 log units) above; the range from low to high includes it.
By their numbers in this assay, from the lowest: compounds 4, 1 and 2 (each within the scatter of the next); then compound 3.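

In this assay, for the compounds shown here, putting hydrogen in place of decylcarbonyl on an oxygen on a saturated carbon gives a 10-fold lower number from compound 3 to compound 4 (1.00 log units; beyond the scatter) and is the only measured single change at this place, so removing this one ester is enough to move the number beyond the scatter. The chain on the ester that remains behaves differently: a 2.0-fold lower number from compound 2 to compound 4 (0.30 log units; within the scatter) and a 1.3-fold lower number from compound 1 to compound 4 (0.10 log units; within the scatter) both lie within the scatter, so the hexanoyl, undecanoyl and dodecanoyl mono-esters of compound 1, compound 4 and compound 2 cannot be placed in any order. Why taking away the decylcarbonyl group shifts the number so much more than changing the chain on the remaining ester is something no available measurement explains.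

The compounds shown leave open whether any ester on this oxygen would give a high number or whether that depends on chain length, which a short acetyl ester in place of the decylcarbonyl group would test. They also leave open whether the flat picture among the mono-esters would hold for a much longer chain, such as octadecanoyl, or for a chain ending in an amine or a carboxylic acid.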